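The source may report more compounds than this note shows. Statements on the series, on what has been measured and on what is new or still open speak of the compounds shown alone.

Compound 2 `COc1cc2c(NCc3ccc(F)cc3)cc(C)nc2cc1OCCCN1CCCC1` gives the lowest number of the two measured compounds in a functional assay on MCF-10A cells (Homo sapiens) for antiproliferative activity, with a stated time of 48 h; a lower number here means that less compound is needed, a higher number that more compound is needed for the effect: compound 2 gives 2100 nM. Among the measured compounds shown here, its nearest neighbour is compound 1 `COc1ccc2nc(-c3ccc(C)o3)cc(NCc3ccc(F)cc3)c2c1`, which in this assay gives 11100 nM; compound 1 differs from compound 2 in more than one place, and no single step joins them. Compound 3 `COc1cc2c(NCc3ccc(F)cc3)cc(-c3ccc(C)o3)nc2cc1OCCCN1CCCC1` is not yet measured. It differs from compound 2 in one place: 5-methylfuran-2-yl in place of methyl on an aromatic carbon. Compound 1 carries the same 5-methylfuran-2-yl group but lacks the pyrrolidinylpropoxy chain of compound 2, so the two measured values do not isolate this change. No direction is expected with confidence; a modest step, possibly beyond the scatter, is the estimate for compound 3, whose value in this assay is expected to be 3500 nM, within a range of 900 nM to 14000 nM, and the step of a 1.7-fold higher number from compound 2 to compound 3 (0.22 log units; within the scatter) is the estimated consequence.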

Compound 3, half-maximal effective concentration: 2100 nM
Estimate against measurement, compound 3: 1.7-fold (0.22 log units) above; low and high end bracket the measured number.
By their numbers in this assay, from the lowest: compounds 2 and 3 (each within the scatter of the next); then compound 1.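

In this assay, 5-methylfuran-2-yl in place of methyl on the aromatic carbon next to the ring nitrogen gives no change at the digits printed from compound 2 to compound 3 (within the scatter), so with the pyrrolidinylpropoxy chain present, this position accepts the five-membered aromatic ring with no change beyond the scatter. With 5-methylfuran-2-yl held constant, 3-(pyrrolidin-1-yl)propoxy in place of hydrogen on an aromatic carbon gives a 5.3-fold lower number from compound 1 to compound 3 (0.72 log units; beyond the scatter), which places the gap seen earlier with the chain rather than with the group at this position. No available evidence accounts for either step.

Going by these compounds, it remains open whether other groups at this position, such as an amine, a carboxylic acid or a phenyl ring, would leave the number equally unchanged. On these data alone, how a longer chain, or a morpholine in place of the pyrrolidine, would compare with compound 3 also remains open.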